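Varying the Sulfonyl Amino Group in a Urea Series

The source may hold more compounds than are shown below. What is called first, only, known or untested is meant among the compounds shown, and "the series" means these compounds.

Compound 1 `CC(C)NS(=O)(=O)NC(=O)Nc1c(C(C)C)cccc1C(C)C` carries an isopropylamino group on the sulfonyl sulfur of the shared core, and in an assay on liver for inhibition of sterol O-acyltransferase 1 (Rattus norvegicus), using microsomes (a lower number here means a stronger inhibitor, a higher number a weaker inhibitor), compound 1 gives 18000 nM. Compound 2 `CCCCN(C)S(=O)(=O)NC(=O)Nc1c(C(C)C)cccc1C(C)C` has butyl(methyl)amino there instead; in this assay compound 2 gives 2300 nM, and the change a 7.8-fold lower number from compound 1 to compound 2 (0.89 log units; beyond the scatter). Compound 3 `CCCN(CCC)S(=O)(=O)NC(=O)Nc1c(C(C)C)cccc1C(C)C` bears dipropylamino, and in this assay compound 3 gives 1100 nM; the changes a 16-fold lower number from compound 1 to compound 3 (1.21 log units; beyond the scatter) and a 2.1-fold lower number from compound 2 to compound 3 (0.32 log units; beyond the scatter). Compound 3 thus holds the lowest of the three numbers, with compound 2 nearest and compound 1 furthest.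

Compound 4 `CCCCN(CC)S(=O)(=O)NC(=O)Nc1c(C(C)C)cccc1C(C)C` differs from compound 3 by one change: butyl(ethyl)amino in place of dipropylamino on a sulfonyl sulfur. The step bearing most directly on it is the modest one between the two groups that each carry two alkyl chains, a 2.1-fold lower number from compound 2 to compound 3 (0.32 log units; beyond the scatter); the larger steps of a 7.8-fold lower number from compound 1 to compound 2 (0.89 log units; beyond the scatter) and a 16-fold lower number from compound 1 to compound 3 (1.21 log units; beyond the scatter) mark the move away from isopropylamino, which compound 4 also leaves behind. Butyl(ethyl)amino lies between butyl(methyl)amino and dipropylamino in how its carbons are distributed, so only a small step is expected, a 1.3-fold higher number from compound 3 to compound 4 (0.10 log units; within the scatter), probably within the scatter and leaning slightly toward a higher number. The estimate for compound 4 in this assay is therefore 1400 nM, with a range from 650 nM to 3000 nM.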

Compound 4, half-maximal inhibitory concentration: 1200 nM
Beside the measured number, compound 4's estimate is 1.2-fold (0.07 log units) above it; the measured number falls inside the stated range.
By their numbers in this assay, from the lowest: compounds 3, 4 and 2 (each within the scatter of the next, the first and the last beyond it); then compound 1.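

In this assay, among these compounds, rejoining the same atoms from dipropylamino into butyl(ethyl)amino on the sulfonyl sulfur gives a 1.1-fold higher number from compound 3 to compound 4 (0.04 log units; within the scatter) and so leaves the read-out unresolved between the two groups, which the earlier compounds could not show, as none of them shared the same atoms. The comparison with butyl(methyl)amino, a 1.9-fold lower number from compound 2 to compound 4 (0.28 log units; within the scatter), also stays within the scatter, and so adding one carbon to the methyl of that group gives no change that can be read, whereas the step from isopropylamino, a 15-fold lower number from compound 1 to compound 4 (1.18 log units; beyond the scatter), is large and of much the same size as the one printed for dipropylamino, a 16-fold lower number from compound 1 to compound 3 (1.21 log units; beyond the scatter). Nothing among the data shown accounts for why these groups read alike at this position.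

The compounds shown leave open whether a longer chain, such as dihexylamino, or a cyclic amine such as piperidine on the sulfonyl sulfur would carry the number beyond the scatter of compound 3. They also leave open how a carboxylic acid or a hydroxyl at the end of one of the chains would read in this assay.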